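This account rests on a few compounds, and the source may have more. Where it says the series, first, only, none or still open, it means among the compounds named here.

Measured so far:
- compound 1, `CSc1nc(NCCCNc2ccnc3cc(Cl)ccc23)c(C#N)c(-c2ccccc2)n1`, gives 20000 nM in an ADME assay on MDCK cells (Canis lupus familiaris) for cytotoxicity, read by microscopy; a higher number here means that more compound is tolerated, a lower number that less compound is tolerated
- compound 2, `CSc1nc(NCCCCNc2ccnc3cc(Cl)ccc23)c(C#N)c(-c2ccccc2)n1`, gives 20000 nM in this assay
- compound 3, `CSc1nc(NCCCCNc2ccnc3cc(Cl)ccc23)c(C#N)c(-c2cccc([N+](=O)[O-])c2)n1`, gives 20000 nM in this assay

Compound 3 stands level with compounds 1 and 2 at the digits shown; it is nearest to compound 1 and furthest from compound 2, but neither gap goes beyond the scatter. Among the measured compounds shown here, the series so far is flat in this assay.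

The next compound is compound 4, `CSc1nc(NCCCCNc2ccnc3cc(Cl)ccc23)c(C#N)c(-c2ccc([N+](=O)[O-])cc2)n1`. It differs from compound 3 in one place: 4-nitrophenyl in place of 3-nitrophenyl on an aromatic carbon. The two share all atoms and differ only in how the nitro group sits on the phenyl ring.

For the measured compounds named here, only one measured step bears on this change, and only loosely: no change at the digits printed from compound 2 to compound 3 (within the scatter). That step introduced the nitro group and left the read-out where it was. Going by the values given here, no measured step shifts a nitro group from one ring carbon to another, so nothing here points to a move in either direction. The expected step from compound 3 to compound 4 is therefore none beyond the scatter, no change at the digits printed from compound 3 to compound 4 (within the scatter).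

Compound 4 is expected to give 20000 nM in this assay, with a range from 10000 nM to 40000 nM.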

Compound 4, minimum cytotoxic concentration: 4000 nM
Compound 4: middle estimate off by 5.0-fold (0.70 log units), on the high side, outside the stated range (below it).
By their numbers in this assay, from the lowest: compound 4; then compounds 1, 2 and 3 (each within the scatter of the next).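

In this assay the nitro group's place on the phenyl ring matters even though the atoms stay the same: 4-nitrophenyl in place of 3-nitrophenyl gives a 5.0-fold lower number from compound 3 to compound 4 (0.70 log units; beyond the scatter) and breaks the flat reading of the series. Adding a nitro group to the plain phenyl can thus leave the number unmoved, with no change at the digits printed from compound 2 to compound 3 (within the scatter) in the 3-nitrophenyl case, or lower it, with a 5.0-fold lower number from compound 2 to compound 4 (0.70 log units; beyond the scatter) in the 4-nitrophenyl case. No measurement at hand accounts for the gap between the two nitrophenyl isomers.

From the compounds shown here alone, whether the lower number is peculiar to the nitro group remains open, since an amine or a carboxylic acid in its place on the phenyl ring could separate the group from its position. Also open, going by these compounds, is whether 4-nitrophenyl has the same effect with a shorter or longer chain between the two ring systems.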